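Oxamide series: aryl in place of cyclohexyl on the amide nitrogen

A few compounds are considered here, and "the series" means these few. Any claim that something is new, unique, unknown or untested is made for them only; others in the source may bear on it.

Measured so far in a functional assay on Jurkat cells (Homo sapiens) for inhibition; a lower number here means a stronger inhibitor, a higher number a weaker inhibitor:
- compound 1 `C[C@H](NC(=O)C(=O)NC1CCCCC1)C(=O)N[C@@H](CC(=O)O)C(=O)COc1c(F)c(F)cc(F)c1F`: 150 nM
- compound 2 `C[C@H](NC(=O)C(=O)Nc1ccccc1C(F)(F)F)C(=O)N[C@@H](CC(=O)O)C(=O)COc1c(F)c(F)cc(F)c1F`: 61 nM

Compound 1 gives the highest of the two numbers in this assay; its nearest neighbour is compound 2, reached by a 2.5-fold lower number from compound 1 to compound 2 (0.39 log units; beyond the scatter). Compound 3 `C[C@H](NC(=O)C(=O)Nc1ccccc1-c1ccc[nH]1)C(=O)N[C@@H](CC(=O)O)C(=O)COc1c(F)c(F)cc(F)c1F` carries the change (2-(1H-pyrrol-2-yl)phenyl in place of cyclohexyl on an amide-type nitrogen). For the measured compounds named here, the only step that bears on it is the aryl-for-cyclohexyl exchange from compound 1 to compound 2, a modest move beyond the scatter, and a step of similar size in the same direction is expected here. For compound 3 the estimate in this assay is 70 nM (range 30 nM to 160 nM), i.e. an expected 2.1-fold lower number from compound 1 to compound 3 (0.33 log units; beyond the scatter).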

Compound 3, half-maximal inhibitory concentration: 56 nM
Beside the measured number, compound 3's estimate is 1.3-fold (0.10 log units) above it; the range from low to high includes it.
By their numbers in this assay, from the lowest: compounds 3 and 2 (each within the scatter of the next); then compound 1.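

In this assay the aryl gain over cyclohexyl on the amide-type nitrogen also holds for 2-(1H-pyrrol-2-yl)phenyl, with a 2.7-fold lower number from compound 1 to compound 3 (0.43 log units; beyond the scatter), so it does not depend on trifluoromethyl alone. Replacing trifluoromethyl with 1H-pyrrol-2-yl on the aromatic carbon gives a 1.1-fold lower number from compound 2 to compound 3 (0.04 log units; within the scatter), and this carbon therefore tolerates either group without separating the two compounds. No available evidence explains either step.

Still open, on these data alone, is how much of the gain an unsubstituted phenyl would retain. Also open, as far as these compounds go, is how an amine or a carboxylic acid on that aromatic carbon would compare.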